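The source may hold more compounds than are shown below. What is called first, only, known or untested is meant among the compounds shown, and "the series" means these compounds.

Compound 1 `COc1ccc(NC(=O)CN2CCN(S(=O)(=O)c3ccc(F)cc3)CC2)cc1` and compound 2 `COc1ccc(NC(=O)CN2CCN(S(=O)(=O)c3ccccc3F)CC2)cc1` share one core; compound 3 `O=C(CN1CCN(S(=O)(=O)c2ccc(F)cc2)CC1)Oc1ccccc1-c1ccccc1` and compound 4 `O=C(CN1CCN(S(=O)(=O)c2ccccc2F)CC1)Oc1ccccc1-c1ccccc1` share another, and the difference between the two cores is not broken down here. Among the compounds with values here, in an in vitro assay on HEK ts201 cells for negative allosteric modulation of Neuronal acetylcholine receptor; alpha3/beta4 (Homo sapiens), read by fluorescence and calcium flux, with a stated time of 1.5 s (on this read-out higher numbers stand for weaker inhibition and lower numbers for stronger inhibition), compound 1 gives 29600 nM and compound 2 gives 19100 nM; the single change 2-fluorophenyl in place of 4-fluorophenyl on a sulfonyl sulfur made the step of a 1.5-fold lower number from compound 1 to compound 2 (0.19 log units; within the scatter). In this assay compound 3 gives 23800 nM, a value that stands within the scatter of both compound 1 and compound 2. The change to compound 4 is 2-fluorophenyl in place of 4-fluorophenyl on a sulfonyl sulfur, the same change at the same place as before. Because the earlier step was a 1.5-fold lower number from compound 1 to compound 2 (0.19 log units; within the scatter), a step of similar size is expected here, a 1.5-fold lower number from compound 3 to compound 4 (0.17 log units; within the scatter). Compound 4 is thus estimated at 16000 nM, with a range from 7000 nM to 40000 nM.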

Compound 4, half-maximal inhibitory concentration: 23500 nM
Compound 4: middle estimate off by 1.5-fold (0.17 log units), on the low side; the range from low to high includes it.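

In this assay the change to 2-fluorophenyl in place of 4-fluorophenyl on a sulfonyl sulfur gives a 1.0-fold lower number from compound 3 to compound 4 (0.01 log units; within the scatter). Set beside the earlier step, the two cores do not separate on this change: the same change on two cores in this assay, a 1.5-fold lower number (0.19 log units; within the scatter) from compound 1 to compound 2 and a 1.0-fold lower number (0.01 log units; within the scatter) from compound 3 to compound 4, 1.5-fold (0.18 log units) apart, within the scatter of two such steps. The change thus carries across these two cores without a readable difference, but both steps lie within the scatter, so this shows no effect of the change on either core and gives no rule for the wider series.

Open, as far as these compounds go, is whether a larger step would appear with a chlorine or a nitrile in place of the fluorine on the ring, or with a methyl in place of the fluorophenyl on the sulfonyl sulfur. Also open, from the compounds shown here alone, is what the single parts of the difference between the two cores contribute.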